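The compounds below may be only part of what the source reports. "The series", "measured", "known", "first", "only" and "open" are said of these compounds alone.

In an ADME assay on cells (spleen, Mus musculus, strain C57BL/6) for inhibition, read by flow cytometry and propidium iodide staining, with a stated time of 24 h, at 37 degrees C (a higher number here means that more compound is needed for the effect, a lower number that less compound is needed), compound 1 `CCC(O)Cc1cn(CC(=O)NCc2ccccc2)nn1` gives 630 uM. Among the compounds with values here, compound 2 `O=C(O)CCc1cn(CC(=O)NCc2ccccc2)nn1` gives 1420 uM, the higher of the two actual numbers so far. Compound 3 `CC(C)(C)OC(=O)NCc1cn(CC(=O)NCc2ccccc2)nn1` stands at > 2000 uM, which is a limit of the assay and not a number. Compound 4 `Cc1ccc(-c2cn(CC(=O)NCc3ccccc3)nn2)cc1` has 4-methylphenyl in place of the 2-carboxyethyl of compound 2, on an aromatic carbon (4-methylphenyl in place of 2-carboxyethyl on an aromatic carbon). The nearest guides are swaps of chain groups, which gave a 2.3-fold higher number from compound 1 to compound 2 (0.35 log units; beyond the scatter), an at least 3.1-fold higher number from compound 1 to compound 3 (0.50 log units; beyond the scatter) and an at least 1.4-fold higher number from compound 2 to compound 3 (0.14 log units; that floor lies within the scatter). None of them brings in an aromatic ring, so they suggest only the size of the change, modest at most, and leave its direction open. The expected change is a 1.6-fold lower number from compound 2 to compound 4 (0.20 log units; within the scatter). For compound 4 the estimate is 900 uM, with an expected range of 300 uM to 2000 uM.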

Compound 4, concentration for half-maximal effect: "non-toxic" (no number reported)
Nothing numeric was reported for compound 4, so the estimate cannot be set against anything.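

Within the data shown here, compound 4 is described only as non-toxic, with no number, so no step from compound 2 to compound 4 can be read. Going by these compounds, whether 4-methylphenyl in place of 2-carboxyethyl raises or lowers the number in this assay stays open.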